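The source may hold more compounds than are shown below. What is called first, only, known or untested is meant among the compounds shown, and "the series" means these compounds.

Measured in a functional assay on HL-60 cells (Homo sapiens) for antiproliferative activity, read by MTT assay, with a stated time of 72 h; a higher number here means a weaker inhibitor, a lower number a stronger inhibitor:
compound 1 `COc1ccc(OCCCON2C(N)=NC(N)=NC23CCOCC3)cc1`: 1670 nM
compound 2 `NC1=NC2(CCSCC2)N(OCCCOc2ccc(Br)cc2)C(N)=N1`: 350 nM
compound 3 `NC1=NC2(CCSCC2)N(OCCCOc2cc(Cl)c(Cl)cc2Cl)C(N)=N1`: 730 nM

Compound 1 gives the highest of the three numbers, with compound 3 nearest to it and compound 2 furthest below it. Compound 4 `NC1=NC2(CCOCC2)N(OCCCOc2ccc(Br)cc2)C(N)=N1` is not yet measured; it differs from compound 1 by bromo in place of methoxy on an aromatic carbon. Among the compounds with values here, the one measured step, a 2.1-fold higher number from compound 2 to compound 3 (0.32 log units; beyond the scatter), concerns another exchange on the aryl ring and does not bear on this one. Within the data shown here, compound 2 carries the same 4-bromophenyl as compound 4 but on a different core, so against compound 1 it changes two places at once; its value shows only that a bromo-bearing analogue lies well below compound 1. A step in this assay toward a lower number is expected for compound 4, estimated at a 2.8-fold lower number from compound 1 to compound 4 (0.44 log units; beyond the scatter), giving 600 nM with a range of 250 nM to 1500 nM.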

Compound 4, half-maximal inhibitory concentration: 310 nM
Estimate against measurement, compound 4: 1.9-fold (0.29 log units) above; the range from low to high includes it.
By their numbers in this assay, from the lowest: compounds 4 and 2 (each within the scatter of the next); then compound 3; then compound 1.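

In this assay, within the data shown here, a 5.4-fold lower number from compound 1 to compound 4 (0.73 log units; beyond the scatter), the first reading of this position with the core held fixed and only 4-methoxyphenyl exchanged for 4-bromophenyl. Compound 4 at 310 nM and compound 2 at 350 nM lie within the scatter of each other, so with 4-bromophenyl in place the two cores are not told apart. Nothing measured here accounts for the size of this step.

Open, on these data alone, is how fluoro, a nitrile or an amine at this place would compare with bromo and methoxy. Also open, as far as these compounds go, is whether 4-methoxyphenyl on the core of compound 2 would match compound 1.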